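Pyridine nitrogen and methyl placement on the shared core

A few compounds are considered here, and "the series" means these few. Any claim that something is new, unique, unknown or untested is made for them only; others in the source may bear on it.

Measured in an assay for binding affinity to metabotropic glutamate receptor 5 (Rattus norvegicus); on this read-out lower numbers stand for stronger inhibition and higher numbers for weaker inhibition:
compound 1 `Cc1ccccc1-c1cc(F)cc(-n2nnc(-c3ccccn3)n2)c1`, 23 nM
compound 2 `Cc1cccnc1-c1cc(F)cc(-n2nnc(-c3ccccn3)n2)c1`, 24 nM
compound 3 `Cc1ccncc1-c1cc(F)cc(-n2nnc(-c3ccccn3)n2)c1`, 2 nM

Compound 2 gives the highest number of the three; compound 1 lies within the scatter of it (a 1.0-fold higher number from compound 1 to compound 2 (0.02 log units; within the scatter)), while compound 3 stands well apart (a 12-fold lower number from compound 2 to compound 3 (1.08 log units; beyond the scatter)). Compound 4 `Cc1cncc(-c2cc(F)cc(-n3nnc(-c4ccccn4)n3)c2)c1` differs from compound 2 by 5-methylpyridin-3-yl in place of 3-methylpyridin-2-yl on an aromatic carbon. Among the compounds with values here, no measured step tests this exact exchange. The nearest is a 12-fold lower number from compound 2 to compound 3 (1.08 log units; beyond the scatter), a change that also brings in a pyridin-3-yl but carries the methyl elsewhere; a 12-fold lower number from compound 1 to compound 3 (1.06 log units; beyond the scatter) points the same way. A lower number in this assay is therefore expected for compound 4, though its size is uncertain. For compound 4 the expected step is a 3.0-fold lower number from compound 2 to compound 4 (0.48 log units; beyond the scatter). The estimate for compound 4 is 8 nM, range 2 nM to 30 nM.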

Compound 4, inhibition constant: 272 nM
Compound 4: the middle estimate sits 34-fold (1.53 log units) below what was measured; measured number outside the range, above it.
By their numbers in this assay, from the lowest: compound 3; then compounds 1 and 2 (each within the scatter of the next); then compound 4.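

Having a pyridin-3-yl at this position does not by itself give a low number in this assay: with an 11-fold higher number from compound 2 to compound 4 (1.05 log units; beyond the scatter) and a 12-fold higher number from compound 1 to compound 4 (1.07 log units; beyond the scatter) both beyond the scatter, 5-methylpyridin-3-yl falls behind both earlier groups. With the same ring, moving the methyl alone gives a 140-fold higher number from compound 3 to compound 4 (2.13 log units; beyond the scatter) and so spans the whole series. Nothing shown explains this gap. Still open, as far as these compounds go, is whether an unsubstituted pyridin-3-yl sits nearer compound 3 or compound 4, and whether an ethyl or methoxy group in place of the methyl of 4-methylpyridin-3-yl keeps the low number of compound 3.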